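Furan-2-yl for bromo in two related purine cores

This account rests on a few compounds, and the source may have more. Where it says the series, first, only, none or still open, it means among the compounds named here.

Measured in a functional assay on CHO cells for antagonist activity at adenosine receptor A2b (Homo sapiens); on this read-out lower numbers stand for stronger inhibition and higher numbers for weaker inhibition:
compound 1 `CCCn1c(Br)nc2c(N)nc(NCCCc3ccccc3)nc21`: 6300 nM
compound 2 `CCCn1c(-c2ccco2)nc2c(N)nc(NCCCc3ccccc3)nc21`: 8240 nM
compound 3 `CCCn1c(Br)nc2c(NCc3ccccc3)ncnc21`: 7490 nM

Compound 1 and compound 2 differ by furan-2-yl in place of bromo on an aromatic carbon; this change gave a 1.3-fold higher number from compound 1 to compound 2 (0.12 log units; within the scatter). Compound 4 `CCCn1c(-c2ccco2)nc2c(NCc3ccccc3)ncnc21` is not yet measured. It stands to compound 3 as compound 2 stands to compound 1: the change is furan-2-yl in place of bromo on an aromatic carbon, the same change at the same place. The difference between the core of compound 1 and the core of compound 3 is not broken down here; in this assay compound 1 and compound 3 give values within the scatter of each other. Going by the values given here, since the one measured instance of this change, a 1.3-fold higher number from compound 1 to compound 2 (0.12 log units; within the scatter), stayed within the scatter, compound 4 is expected to move from compound 3 by about a 1.2-fold higher number from compound 3 to compound 4 (0.08 log units; within the scatter). Compound 4 is therefore estimated at 9000 nM in this assay, with a likely range from 4000 nM to 20000 nM.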

Compound 4, inhibition constant: 1760 nM
The estimate for compound 4 lay 5.1-fold (0.71 log units) above the measured number, outside the stated range (below it).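

In this assay, furan-2-yl in place of bromo gave a 4.3-fold lower number from compound 3 to compound 4 (0.63 log units; beyond the scatter), so the result on the core of compound 1 did not carry over to the core of compound 3: the same change on two cores in this assay, a 1.3-fold higher number (0.12 log units; within the scatter) from compound 1 to compound 2 and a 4.3-fold lower number (0.63 log units; beyond the scatter) from compound 3 to compound 4, 5.6-fold (0.75 log units) apart, beyond the scatter of two such steps. In these two pairs, the step read on one core therefore did not foretell the step on the other. Which difference between the two cores goes with this gap is not shown, as the compounds shown do not separate those differences, and two pairs set no rule for other cores.

Going by these compounds, it remains open whether the lower number on the core of compound 3 is specific to furan-2-yl or also appears with thiophen-2-yl or phenyl at the same carbon. On these data alone, the effect of replacing propyl with a longer chain such as butyl also remains open.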